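The compounds below may be only part of what the source reports. "The series", "measured", "known", "first", "only" and "open" are said of these compounds alone.

Of the compounds shown here, three have been measured in a functional assay on CHO cells for antagonist activity at corticotropin-releasing factor receptor 1 (Homo sapiens), read by cAMP accumulation; a higher number here means a weaker inhibitor, a lower number a stronger inhibitor. Compound 1 `CCCCN(CC)c1nc(C)nc2c1c(C)nn2-c1c(C)cc(C)cc1C` gives 9 nM. Compound 2 `CCCN(CC(=O)N(C)C)c1nc(C)nc2c1c(C)nn2-c1ccc(OC)cc1C` gives 1410 nM. Compound 3 `CCCNCc1nc(Nc2nc(C)nc3c2c(C)nn3-c2ccc(OC)cc2C)no1` gives 124 nM, the second highest of the three numbers: it lies well below compound 2 and well above compound 1, and both of those gaps are beyond the scatter. Compound 4 `CC[C@H](COC)Nc1nc(C)nc2c1c(C)nn2-c1ccc(OC)cc1C` has not yet been measured. It differs from compound 3 in one place: 1-(methoxymethyl)propyl in place of 5-((propylamino)methyl)-1,2,4-oxadiazol-3-yl on a nitrogen on an aromatic ring. In plain terms, the group that carries a five-membered aromatic ring is replaced by a short branched chain with a methyl ether, so compound 4 loses that ring and keeps the rest of the shared core. Within the data shown here, no measured pair shows exactly this swap, so the size of the step cannot be read off directly. Still, compound 1, which also carries a group without a ring on that nitrogen, gives 9 nM, the lowest number of the set, and that makes a move toward a lower number the more likely outcome. Compound 4 is therefore expected to give about 15 nM, with a range from 4 nM to 60 nM. The expected step from compound 3 to compound 4 is an 8.3-fold lower number from compound 3 to compound 4 (0.92 log units; beyond the scatter), a fall beyond the scatter.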

Compound 4, inhibition constant: 210 nM
The estimate for compound 4 lay 14-fold (1.15 log units) below the measured number; measured number above the stated range.
By their numbers in this assay, from the lowest: compound 1; then compounds 3 and 4 (each within the scatter of the next); then compound 2.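

In this assay, putting 1-(methoxymethyl)propyl in place of 5-((propylamino)methyl)-1,2,4-oxadiazol-3-yl on a nitrogen on an aromatic ring gives a 1.7-fold higher number from compound 3 to compound 4 (0.23 log units; within the scatter) and so leaves the number within the scatter, even though the group that leaves has a five-membered aromatic ring and 10 heavy atoms while the group that enters has no ring and 6 heavy atoms. The choice of group at this part of the shared core can still matter, as (1-(methoxymethyl)propyl)amino in place of ((dimethylcarbamoyl)methyl)(propyl)amino on an aromatic carbon gives a 6.7-fold lower number from compound 2 to compound 4 (0.83 log units; beyond the scatter) in a step described as modest. No data here bear on why these two steps came out as they did.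

The compounds shown leave open whether the one defined stereocentre of compound 4 counts, as the opposite arrangement does not appear among them. They also leave open whether the methyl ether itself matters, which a plain butyl chain in place of 1-(methoxymethyl)propyl would test, and how an amine at the end of that chain would read.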